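The source may report more compounds than this note shows. Statements on the series, on what has been measured and on what is new or still open speak of the compounds shown alone.

Measured so far:
Compound 1 `COc1ccc(C2=C(c3cc(OC)c(OC)c(OC)c3)C(=O)C(O[SiH2]C(C)(C)C)C2)cc1OC(C)C` gives 7.5 ug/mL in an ADME assay on KB cells (Homo sapiens) for cytotoxicity, read by MTT assay, with a stated time of 72 h; on this read-out higher numbers stand for weaker inhibition and lower numbers for stronger inhibition.
Compound 2 `COC(=O)c1cc(C2=C(c3cc(OC)c(OC)c(OC)c3)C(=O)CC2O[SiH2]C(C)(C)C)ccc1OC` gives only a limit, > 100 ug/mL, in this assay.

Compound 2 therefore stands at the upper edge of the numbers seen here, at the limit of > 100 ug/mL in this assay, at which 1 of the 2 values shown sits, while compound 1 sits well inside the measurable range. Among the measured compounds shown here, the two differ in several places at once, so no single step is drawn between them. Compound 3 `COc1ccc(OC)c(C2=C(c3cc(OC)c(OC)c(OC)c3)C(=O)CC2O[SiH2]C(C)(C)C)c1` is compound 2 with one change: 2,5-dimethoxyphenyl in place of 4-methoxy-3-(methoxycarbonyl)phenyl on a double-bonded ring carbon. For the measured compounds named here, no measured step of this kind is available, so the direction is open. Starting from a limit, any real change can only show itself as a move downward into the measurable range. For compound 3 the estimate is 60 ug/mL, with a range from 15 ug/mL to 200 ug/mL. This means an expected step of an at least 1.6-fold lower number from compound 2 to compound 3 (0.22 log units; that floor lies within the scatter), judged modest, with a fair chance that compound 3 again returns only a limit.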

Compound 3, half-maximal inhibitory concentration: 10 ug/mL
Beside the measured number, compound 3's estimate is 6.0-fold (0.78 log units) above it; the measured number lies below the stated range.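

In this assay, 2,5-dimethoxyphenyl in place of 4-methoxy-3-(methoxycarbonyl)phenyl on a double-bonded ring carbon gives an at least 10-fold lower number from compound 2 to compound 3 (1.00 log units; beyond the scatter). Among the compounds shown here, this is the first comparison here in which only one place differs, and it shows that the aromatic group at this place can carry a compound from a limit into the measurable range. Compound 2 remains a limit and not a number, so the step has only a floor and its full size stays unknown: the limit of > 100 ug/mL in this assay, at which 1 of the 3 values shown sits.

The exchange removes the methoxycarbonyl group and also rearranges the methoxy groups on the ring, so the compounds shown do not separate these two changes. They also leave open how this place would respond to a phenyl ring bearing an amine or a carboxylic acid.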